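Replacing a Piperidinyl Ketone with a Tertiary Alcohol

This account rests on a few compounds, and the source may have more. Where it says the series, first, only, none or still open, it means among the compounds named here.

Measured compounds:
Compound 1 `O=C1O[C@@H](Cn2ccnn2)CN1c1ccc(-c2ccc(C(O)C3CNC3)nc2)c(F)c1` gives 58000 nM in an assay for inhibition of Amine oxidase [flavin-containing] A (Homo sapiens); on this read-out higher numbers stand for weaker inhibition and lower numbers for stronger inhibition.
Compound 2 `O=C(c1ccc(-c2ccc(N3C[C@H](Cn4ccnn4)OC3=O)cc2F)cn1)C1CCNCC1` gives > 44000 nM in this assay.

Compound 2 stands at a limit of this assay and not at a number; of the two values shown, this is the one sitting at the limit of > 44000 nM in this assay, at which 1 of the 2 values shown sits. Among the measured compounds shown here, the only measured step, a step that the limit leaves unreadable from compound 1 to compound 2, leads into that limit and its size cannot be read. Compound 3 `CC(C)(O)c1ccc(-c2ccc(N3C[C@H](Cn4ccnn4)OC3=O)cc2F)cn1` is derived from compound 2 by the change (1-hydroxy-1-methylethyl in place of (piperidin-4-yl)carbonyl on an aromatic carbon). No measured step concerns this exchange: the single step from compound 1 to compound 2 swaps different groups and its size is hidden by the limit, so nothing shown speaks for a direction of the change from compound 2 to compound 3 in this assay. Compound 3 is therefore expected to remain weak, with an estimated step that the limit leaves unreadable from compound 2 to compound 3 that is not beyond the scatter. Compound 3 is estimated at 60000 nM in this assay, within a range from 20000 nM to 200000 nM.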

Compound 3, inhibition constant in the Amine oxidase [flavin-containing] A assay: 6000 nM
Beside the measured number, compound 3's estimate is 10-fold (1.00 log units) above it; the whole stated range lies above it.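

Among the compounds shown here, in the Amine oxidase [flavin-containing] A assay, 1-hydroxy-1-methylethyl in place of (piperidin-4-yl)carbonyl on this aromatic carbon gives an at least 7.3-fold lower number from compound 2 to compound 3 (0.86 log units; beyond the scatter), the first sign that an exchange at this position can move the read-out towards stronger inhibition. The same group in place of (azetidin-3-yl)(hydroxy)methyl gives a 9.7-fold lower number from compound 1 to compound 3 (0.99 log units; beyond the scatter), so compound 3 separates beyond the scatter from both earlier compounds, even though the group it carries is the smaller one and has no ring. In the Amine oxidase [flavin-containing] A assay compound 2 gives > 44000 nM, which is a limit and not a number, so the step into compound 3 gives only a bound on its size, and the step from compound 1 to compound 2 stays unreadable: the limit of > 44000 nM in the Amine oxidase [flavin-containing] A assay, at which 1 of the 3 values shown sits.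

From the compounds shown here alone, whether an amine, a carboxylic acid or a longer chain on this carbon would take the read-out further remains open, as does whether the hydroxy group of 1-hydroxy-1-methylethyl is needed for the step at all. In a physicochemical assay for solubility, read by nephelometry (on this read-out higher numbers stand for higher solubility and lower numbers for lower solubility), compound 2 gives 100000 nM and compound 3 gives 200000 nM. In the physicochemical assay the same exchange gives a 2.0-fold higher number from compound 2 to compound 3 (0.30 log units; within the scatter), so the compounds shown separate no difference in solubility between compound 2 and compound 3.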